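Lipoic acid coumarin conjugates: from carboxy to methoxyphenyl

This account rests on a few compounds, and the source may have more. Where it says the series, first, only, none or still open, it means among the compounds named here.

Measured compounds:
compound 1, `O=C(CCCCC1CCSS1)NCc1cn(CCCOc2ccc3ccc(=O)oc3c2)nn1`, 37.8%
compound 2, `O=C(CCCCC1CCSS1)NCc1cn(CCCOc2ccc3cc(C(=O)O)c(=O)oc3c2)nn1`, 43.4%

The series shares one core, a dithiolane-bearing amide joined through a triazole and a propyl linker to a coumarin. In a functional assay on PC-12 cells (Rattus norvegicus) for cytotoxicity, read by MTT assay, with stated times of 3 h and 2 h, tested at 0.1 uM (on this read-out higher numbers stand for a stronger effect at the one concentration tested and lower numbers for a weaker effect), compound 1 gives 37.8%. In this assay compound 2 gives 43.4%. Compound 2 holds the higher of the two numbers, with compound 1 nearest; the step between them is a number 5.6 percentage points higher from compound 1 to compound 2 (within the scatter), so the two cannot be told apart.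

Compound 3, `COc1ccc(-c2cc3ccc(OCCCn4cc(CNC(=O)CCCCC5CCSS5)nn4)cc3oc2=O)cc1`, is not yet measured in this assay. It differs from compound 2 in one place:
4-methoxyphenyl in place of carboxy on an aromatic carbon

Within the data shown here, only one measured step exists, a number 5.6 percentage points higher from compound 1 to compound 2 (within the scatter), and it concerns the same aromatic carbon; it lies within the scatter. Nothing here shows that a change at that position shifts the read-out. The expected step for compound 3 in this assay is therefore a number 3.4 percentage points lower from compound 2 to compound 3 (within the scatter), none beyond the scatter. Compound 3 is estimated at 40%, with a range from 25% to 55%.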

Compound 3, a percentage reported as activity, at one concentration (the size of the read-out at that concentration, not a potency): 42%
Compound 3: middle estimate off by 2 percentage points, on the low side; the range from low to high includes it.
By their numbers in this assay, from the lowest: compounds 1, 3 and 2 (each within the scatter of the next).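

Putting 4-methoxyphenyl in place of carboxy on this aromatic carbon gives a number 1.4 percentage points lower from compound 2 to compound 3 (within the scatter) in this assay and so exchanges a group of 3 heavy atoms with a hydrogen-bond donor for one of 8 heavy atoms with a six-membered aromatic ring of carbon only and no hydrogen-bond donor. The same group in place of hydrogen gives a number 4.2 percentage points higher from compound 1 to compound 3 (within the scatter) and shows that this aromatic carbon, two atoms from the ring oxygen, has now carried hydrogen, carboxy and a far larger aryl group in these three compounds without any step leaving the scatter, whereas the earlier pair had tested only carboxy against hydrogen. No other data bear on what lies behind these numbers.

Still open is whether an amine or a long alkyl chain on this aromatic carbon would give a step beyond the scatter, since the three groups shown cannot settle that. Also open, from the compounds shown here alone, is whether a longer chain in place of the propyl linker would change the read-out, and whether these compounds stay indistinguishable at any concentration other than the single one tested.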